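A few compounds are considered here, and "the series" means these few. Any claim that something is new, unique, unknown or untested is made for them only; others in the source may bear on it.

Measured in a functional assay on HUVEC cells (Homo sapiens) for antiproliferative activity, read by MTT assay, with a stated time of 24 h; a higher number here means a weaker inhibitor, a lower number a stronger inhibitor:
Compound 1 `C=CCc1cc(-c2cccc(C(F)(F)F)c2)ccc1O`: 76000 nM
Compound 2 `C=CCc1cc(-c2ccccc2)ccc1O`: > 100000 nM (a limit, not a number)

From the compounds shown here alone, compound 2 stands only at a limit, so its true position is unknown: the limit of > 100000 nM in this assay, at which 1 of the 2 values shown sits.

Compound 3 `C=CCc1cc(-c2cccc(SC)c2)ccc1O` differs from compound 2 by methylsulfanyl in place of hydrogen on an aromatic carbon, meta to a large group. Compound 3 thus carries methylsulfanyl where compound 1 carries trifluoromethyl.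

Among the measured compounds shown here, one measured step bears on this change: an at least 1.3-fold higher number from compound 1 to compound 2 (0.11 log units; that floor lies within the scatter). Its size is only a floor, and it gives no firm measure of what a group at this place does. Read in reverse, it points towards a lower number once the hydrogen is replaced, but only weakly. A small drop is therefore expected in this assay, possibly none beyond the scatter, and another reading at the limit would be no surprise.

For the measured compounds named here, the expectation leans on compound 1 at 76000 nM, the only number. For compound 3 the expected value is 80000 nM, with an estimated range of 40000 nM to 100000 nM. This estimate means an expected at least 1.2-fold lower number from compound 2 to compound 3 (0.09 log units; that floor lies within the scatter).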

Compound 3, half-maximal inhibitory concentration: > 100000 nM
Compound 3 gave a limit, no number; the forecaster's own chance of this, stated with the estimate: 40%; middle value at least 1.2-fold (0.09 log units) away from the limit.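

In this assay, methylsulfanyl on the aromatic carbon, meta to a large group, gives no readable value: compound 3 reads > 100000 nM, a limit and not a number. The step from hydrogen to methylsulfanyl therefore cannot be read, and the series now gathers at a single limit: the limit of > 100000 nM in this assay, at which 2 of the 3 values shown sit. Against trifluoromethyl, the exchange gives an at least 1.3-fold higher number from compound 1 to compound 3 (0.11 log units; that floor lies within the scatter), so the data offer only a floor that does not separate methylsulfanyl from trifluoromethyl at this place, and the weak hint from the earlier pair, that a group here might lower the number, gains no support from a second group.

Among the compounds shown here, compound 1 remains the only compound with a number, so it is still open whether any group at this place can produce a step beyond the scatter, and whether the true values of compound 2 and compound 3 differ at all. Also open, from the compounds shown here alone, is how an amine, a carboxylic acid or a longer chain at this carbon would read in this assay, and whether any of them would give a second number.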